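This account rests on a few compounds, and the source may have more. Where it says the series, first, only, none or still open, it means among the compounds named here.

Values in a functional assay on HL-60 cells (Homo sapiens) for inhibition, read by MTT assay, with a stated time of 48 h; a higher number here means a weaker inhibitor, a lower number a stronger inhibitor:
- compound 1 `O=C(/C=C/c1ccccc1)c1ccc[nH]1`: > 100000 nM, a limit of the assay and not a number
- compound 2 `O=C(/C=C/c1cccc([N+](=O)[O-])c1)c1ccco1`: 14000 nM

Within the data shown here, compound 2 gives 14000 nM, the only true number in this assay so far, so it cannot yet be ranked against a second number. The next compound to be measured is compound 3 `O=C(/C=C/c1ccccc1)c1ccco1`, which has hydrogen in place of nitro on an aromatic carbon of a six-membered aromatic ring of carbon only: hydrogen in place of nitro on an aromatic carbon. Among the measured compounds shown here, no measured pair isolates this change, so its size in this assay rests on judgement alone. A moderate weakening beyond the usual scatter is expected, and a result reported only as a limit remains possible. The estimated change is a 2.9-fold higher number from compound 2 to compound 3 (0.46 log units; beyond the scatter). Compound 3 is expected to give 40000 nM, with an estimated range of 14000 nM to 100000 nM.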

Compound 3, half-maximal inhibitory concentration: 100000 nM
Beside the measured number, compound 3's estimate is 2.5-fold (0.40 log units) below it, and the stated range covers the measured number.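

Within this assay, the aromatic carbon of the six-membered ring that is meta to a group of 9 heavy atoms now has its first readable change: with hydrogen in place of nitro, the series shows a 7.1-fold higher number from compound 2 to compound 3 (0.85 log units; beyond the scatter). This single pair ties the stronger inhibition of compound 2 to the nitro group, though the step is modest and rests on one furan-2-yl pair. The series shows a number no higher from compound 1 to compound 3 (the limit leaves the size open) with furan-2-yl in place of 1H-pyrrol-2-yl. Compound 1 stands at a limit of the assay and not a number: the limit of > 100000 nM in this assay, at which 1 of the 3 values shown sits.

As far as these compounds go, whether the step belongs to nitro in particular remains open, as an amine, a carboxylic acid or a methoxy group on the same aromatic carbon would test. Also open, from the compounds shown here alone, is whether nitro gives a step of similar size on the core of compound 1.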